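A few compounds are considered here, and "the series" means these few. Any claim that something is new, unique, unknown or untested is made for them only; others in the source may bear on it.

Measured compounds:
- compound 1 `Cn1c(=O)[nH]c2cc(OCc3ccccc3)ccc21`, "not determined" (no result reported)
- compound 2 `Cn1c(=O)[nH]c2ccc(OCc3cccc(F)c3)cc21`, "not determined" (no result reported)
- compound 3 `O=C1Nc2ccc(OCc3cccc(Cl)c3)cc2C1=O`, 311000 nM

Three compounds were taken into an assay on cells for inhibition of Amine oxidase [flavin-containing] A (Homo sapiens), read by fluorescence, with stated times of 30 min and 15 min; a higher number here means a weaker inhibitor, a lower number a stronger inhibitor. For compound 1 `Cn1c(=O)[nH]c2cc(OCc3ccccc3)ccc21` and compound 2 `Cn1c(=O)[nH]c2ccc(OCc3cccc(F)c3)cc21` no single number was reported. Within the data shown here, compound 3 `O=C1Nc2ccc(OCc3cccc(Cl)c3)cc2C1=O` therefore carries the only number in this assay, and in this assay compound 3 gives 311000 nM, a very weak result that leaves it at the top of the sheet by default, with nothing measured to compare against.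

Compound 4 `O=C1Nc2ccc(OCc3ccc(Cl)c(Cl)c3)cc2C1=O` has not yet been measured. It differs from compound 3 in one place: chloro in place of hydrogen on an aromatic carbon. The new chloro sits ortho to a chloro group and para to a large group, on an aromatic carbon of a six-membered aromatic ring of carbon only.

Among the measured compounds shown here, no step between two measured compounds is available, so the size of the change cannot be read from earlier pairs. With a single added atom on an already very weak compound, the expected step from compound 3 to compound 4 is a 1.4-fold lower number from compound 3 to compound 4 (0.15 log units; within the scatter), a shift that is not expected to exceed the usual scatter. For compound 4 the estimate in this assay is 220000 nM, with a range from 70000 nM to 700000 nM.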

Compound 4, half-maximal inhibitory concentration: 117000 nM
The estimate for compound 4 lay 1.9-fold (0.27 log units) above the measured number; measured number inside the range.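

Adding a second chloro on this aromatic carbon, ortho to a chloro group and para to a large group, gives a 2.7-fold lower number from compound 3 to compound 4 (0.42 log units; beyond the scatter) in this assay. Among these compounds, this is the first step that can be read, and it shows that a single added chloro at this position can move the number modestly towards stronger inhibition, although compound 4 remains a weak inhibitor at 117000 nM. No measured evidence accompanies the result that would explain the shift.

The compounds shown leave open whether another group on this same carbon, such as a methoxy group, an amine or a carboxylic acid, would move the number as far or in the same direction. They also leave open whether the same chloro would give a similar step on the core of compound 1.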